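The compounds below may be only part of what the source reports. "The series", "measured", "known", "first", "only" and "open" are said of these compounds alone.

Measured so far in a functional assay on BGC-823 cells (Homo sapiens) for inhibition, read by MTT assay, with a stated time of 72 h; on this read-out lower numbers stand for stronger inhibition and higher numbers for weaker inhibition. Compound 1 `C[C@@H]1CCN(c2cc(-c3ccccc3)nc3ncnn23)C[C@@H]1N(C)c1ncnc2[nH]ccc12` gives only a limit of this assay, > 100000 nM. Compound 2 `C=CCSc1nc2nc(C)cc(N3CC[C@@H](C)[C@@H](N(C)c4ncnc5[nH]ccc45)C3)n2n1` gives 40900 nM. Compound 3 `CCCCCc1c(C)nc2nc(SCc3ccc(Cl)cc3)nn2c1N1CC[C@@H](C)[C@@H](N(C)c2ncnc3[nH]ccc23)C1` gives 32300 nM.

Among the two plain numbers, compound 2 has the higher one, but compound 3 lies so close that the gap falls within the usual scatter of repeated measurements, so no order between them can be read. Compound 1 stands apart only as a limit, which says no more than that the assay reached its edge.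

Compound 4 `C#CSc1nc2nc(C)cc(N3CC[C@@H](C)[C@@H](N(C)c4ncnc5[nH]ccc45)C3)n2n1` differs from compound 2 in one place: ethynyl in place of allyl on a sulfur. For the measured compounds named here, no pair of measured compounds differs in a single place, so the measured set holds no step that shows how a change of this kind moves the numbers here. The step from compound 2 to compound 4 is therefore expected to be small, within the scatter and in no settled direction, as a 1.1-fold higher number from compound 2 to compound 4 (0.04 log units; within the scatter). Compound 4 is estimated at 45000 nM, with a likely range from 15000 nM to 130000 nM.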

Compound 4, half-maximal inhibitory concentration: 62100 nM
Compound 4: the middle estimate sits 1.4-fold (0.14 log units) below what was measured; measured number inside the range.
By their numbers in this assay, from the lowest: compounds 3, 2 and 4 (each within the scatter of the next). At a limit, above all of these: compound 1.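

For the compounds shown here, the first pair in this set that differs in one place shows that, in this assay, putting ethynyl in place of allyl on a sulfur gives a 1.5-fold higher number from compound 2 to compound 4 (0.18 log units; within the scatter). The two sulfur groups therefore cannot be told apart here, even though ethynyl has a triple bond and one heavy atom fewer than allyl, which has a double bond. Compound 1 marks the edge of what this assay reports: the limit of > 100000 nM in this assay, at which 1 of the 4 values shown sits.

On these data alone, whether a group of another kind on this sulfur, such as an amine, a carboxylic acid or a longer chain, would move the number beyond the scatter remains open. Compound 3 differs from compound 2 in more than one place, so it cannot settle that question.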